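This account rests on a few compounds, and the source may have more. Where it says the series, first, only, none or still open, it means among the compounds named here.

Of the compounds shown here, two from this series have been tested so far. Compound 1 `CC(=O)NC1CCN(c2nc3c(c(Nc4ccc(C(F)(F)F)cc4)n2)CCN(c2ncccc2C(F)(F)F)CC3)C1` and compound 2 `FC(F)(F)c1ccc(Nc2nc(N3CCN(C4CCC4)CC3)nc3c2CCN(c2ncccc2C(F)(F)F)CC3)cc1` share the same core and differ in one place; in a functional assay on HEK293 cells for antagonist activity at transient receptor potential cation channel subfamily V member 1 (Rattus norvegicus), read by FLIPR and calcium flux (on this read-out lower numbers stand for stronger inhibition and higher numbers for weaker inhibition), compound 1 gives 410 nM, and compound 2 gives 161 nM. That change, a 2.5-fold lower number from compound 1 to compound 2 (0.41 log units; beyond the scatter), makes compound 2 the lowest of the two numbers measured in this assay, with compound 1 as its nearest neighbour.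

The next compound, compound 3 `CCC(CC)N1CCN(c2nc3c(c(Nc4ccc(C(F)(F)F)cc4)n2)CCN(c2ncccc2C(F)(F)F)CC3)CC1`, differs from compound 2 by a smaller alteration: pentan-3-yl in place of cyclobutyl on an amine nitrogen in a ring. Within the data shown here, no measured step in this set swaps one such group for another on that ring nitrogen, so the step from compound 1 to compound 2 bears on it only loosely, as a sign that this part of the molecule tolerates change. With nothing pointing in either direction, no step beyond the scatter is expected, so that compound 3 is estimated to come in at 160 nM (between 60 nM and 450 nM), a step of a 1.0-fold lower number from compound 2 to compound 3 (0.00 log units; within the scatter) from compound 2.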

Compound 3, half-maximal inhibitory concentration in the transient receptor potential cation channel subfamily V member 1 assay: 185 nM
Beside the measured number, compound 3's estimate is 1.2-fold (0.06 log units) below it; the range from low to high includes it.
By their numbers in the transient receptor potential cation channel subfamily V member 1 assay, from the lowest: compounds 2 and 3 (each within the scatter of the next); then compound 1.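

In the transient receptor potential cation channel subfamily V member 1 assay the swap at the ring nitrogen gives a 1.1-fold higher number from compound 2 to compound 3 (0.06 log units; within the scatter), and compound 3 stays clear of the acetamide compound, with a 2.2-fold lower number from compound 1 to compound 3 (0.35 log units; beyond the scatter). In a physicochemical assay for solubility, in simulated intestinal fluid, measured as thermodynamic solubility, at pH 6.8 (a lower number here means a less soluble compound, a higher number a more soluble compound), the numbers move far more: compound 2 gives 2 ug/mL and compound 3 gives 109 ug/mL. So at this amine nitrogen, pentan-3-yl in place of cyclobutyl raises solubility in simulated intestinal fluid while the inhibition stays within the scatter, which the first step alone could not show: the measured solubility of compound 2, 2 ug/mL, and of compound 3, 109 ug/mL, a 55-fold higher number (1.74 log units; beyond the scatter)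

With only these two groups, the effect of opening the ring cannot be told apart from that of the added carbon. A cyclopentyl or an isopropyl group on the same nitrogen would separate the two.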